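Swapping diethylamino for chloro on compound 2

The source may report more compounds than this note shows. Statements on the series, on what has been measured and on what is new or still open speak of the compounds shown alone.

Compound 2 `CCN(CC)c1ccc(/C=C/C(=O)c2ccc(OC)c3c2OC(C)(C)C=C3)cc1` gives 610 nM in a functional assay on SK-OV-3 cells (Homo sapiens) for antiproliferative activity, read by MTT assay, with a stated time of 24 h (a higher number here means a weaker inhibitor, a lower number a stronger inhibitor), the only number shown among the two measured compounds. Compound 1 `COc1cc(OC)c(OC)cc1/C=C/C(=O)c1ccc(OC)c2c1OC(C)(C)C=C2` reaches only a limit of > 10000 nM in this assay, as the evidence notes (the limit of > 10000 nM in this assay, at which 1 of the 2 values shown sits). Compound 3 `COc1ccc(C(=O)/C=C/c2ccc(Cl)cc2)c2c1C=CC(C)(C)O2` differs from compound 2 in one place: chloro in place of diethylamino on an aromatic carbon. Among the compounds with values here, no step between measured compounds is recorded, so the size of this change is uncertain; a loss of potency beyond the usual scatter is expected, with the estimated step of a 4.9-fold higher number from compound 2 to compound 3 (0.69 log units; beyond the scatter). Compound 3 is expected to give 3000 nM in this assay, within 800 nM to 20000 nM.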

Compound 3, half-maximal inhibitory concentration: > 10000 nM
Compound 3 gave a limit, no number (the forecaster's own chance of this, stated with the estimate: 35%); middle value at least 3.3-fold (0.52 log units) away from the limit.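

Putting chloro in place of diethylamino on this aromatic carbon gives an at least 16-fold higher number from compound 2 to compound 3 (1.21 log units; beyond the scatter), so the activity of compound 2 in this assay depends strongly on the group at this position. From the compounds shown here alone, compound 3 gives > 10000 nM, which is a limit and not a number, so the full size of the loss stays unknown. Most of the values shown now rest at this ceiling: the limit of > 10000 nM in this assay, at which 2 of the 3 values shown sit.

Going by these compounds, whether the activity needs the nitrogen itself or its two ethyl chains stays open. A plain amine or a dimethylamino group at this position would separate the two.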